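The compounds below may be only part of what the source reports. "The series", "measured", "known", "first", "only" and "open" are said of these compounds alone.

Measured so far in an assay on isolated protein for inhibition of Dihydrofolate reductase (Mus musculus); on this read-out higher numbers stand for higher potency (the scale is a negative logarithm) and lower numbers for lower potency:
compound 1, `CC1(C)N=C(N)N=C(N)N1c1ccc(OCc2cccc(S(=O)(=O)F)c2)c(Cl)c1`: 7.72
compound 2, `CC1(C)N=C(N)N=C(N)N1c1ccc(OCc2ccc(Cl)c(S(=O)(=O)F)c2)c(Cl)c1`: 8
compound 3, `CC1(C)N=C(N)N=C(N)N1c1ccc(OCCCNC(=O)Nc2cccc(S(=O)(=O)F)c2)cc1`: 7.32

Among the measured compounds shown here, the one counted step is chloro in place of hydrogen on an aromatic carbon, which gave a number 0.28 log units higher from compound 1 to compound 2 (within the scatter). Compound 3 shares the core but carries a different side chain; how the two cores differ is not broken down here. Compound 4, `CC1(C)N=C(N)N=C(N)N1c1ccc(OCCCNC(=O)Nc2cccc(S(=O)(=O)F)c2)c(Cl)c1`, arises from compound 3 by chloro in place of hydrogen on an aromatic carbon. For the measured compounds named here, this is the same kind of change as the one from compound 1 to compound 2, not the same: there the chloro entered ortho to a fluorosulfonyl group and para to a large group, here it enters ortho to a large group and meta to a large group. Compounds 1 and 2 both already bear chloro at that place. The expected step is a number 0.48 log units higher from compound 3 to compound 4 (beyond the scatter), resting on the earlier step of a number 0.28 log units higher from compound 1 to compound 2 (within the scatter) while allowing for the different surroundings. Compound 4 is therefore estimated at 7.8, between 7.4 and 8.3.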

Compound 4, logarithm of the reciprocal of the active concentration, log(1/C): 7.28
Compound 4: the middle estimate sits 0.52 log units above what was measured; the whole stated range lies above it.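

In this assay, chloro in place of hydrogen on an aromatic carbon gives a number 0.04 log units lower from compound 3 to compound 4 (within the scatter), so on this core the change has no effect that can be told from the scatter. Among the compounds shown here, the change does not separate the two cores, although the chloro enters at different places in the two pairs: the same change on two cores in this assay, a number 0.28 log units higher (within the scatter) from compound 1 to compound 2 and a number 0.04 log units lower (within the scatter) from compound 3 to compound 4, 0.32 log units apart, within the scatter of two such steps Two pairs show only that neither step leaves the scatter; they do not show that the change would stay this small on other cores or at other places, and they explain neither step.

Left open is how bromo or methoxy at the same aromatic carbon would compare with chloro. Also open, as far as these compounds go, is whether the chloro step holds with a longer chain in the side chain of compound 3, or with an amine in place of the fluorosulfonyl group.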